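This account rests on a few compounds, and the source may have more. Where it says the series, first, only, none or still open, it means among the compounds named here.

Measured compounds in a functional assay on A549 cells (Homo sapiens) for cytotoxicity, read by MTT assay, with a stated time of 24 h; a higher number here means a weaker inhibitor, a lower number a stronger inhibitor:
- compound 1 `FC(F)(F)Oc1ccc(-c2cc(COc3ccccc3-c3nc4ccccc4s3)on2)cc1`, 23900 nM
- compound 2 `Brc1ccc(-c2cc(COc3ccccc3-c3nc4ccccc4s3)on2)cc1`, 19200 nM
- compound 3 `Fc1ccc(-n2cc(COc3ccccc3-c3nc4ccccc4s3)nn2)cc1`, 23300 nM

Compound 2 gives the lowest of these three numbers, but its gaps to compound 1 and compound 3 are both within the usual scatter, so the three read as one level. Compound 4 `COc1ccc(-c2cc(COc3ccccc3-c3nc4ccccc4s3)on2)cc1` differs from compound 2 by methoxy in place of bromo on an aromatic carbon. For the measured compounds named here, the only measured step at the same place is a 1.2-fold lower number from compound 1 to compound 2 (0.10 log units; within the scatter), which did not leave the scatter. A swap of one small group for another at this position has thus shown no shift, and the estimate for a 1.0-fold higher number from compound 2 to compound 4 (0.02 log units; within the scatter) is likewise no change beyond the scatter. Compound 4 is expected to give 20000 nM, within a range of 8000 nM to 50000 nM.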

Compound 4, half-maximal inhibitory concentration: 24100 nM
Compound 4: middle estimate off by 1.2-fold (0.08 log units), on the low side; the range from low to high includes it.
By their numbers in this assay, from the lowest: compounds 2, 3, 1 and 4 (each within the scatter of the next).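

In this assay, methoxy sits at the same level as bromo (a 1.3-fold higher number from compound 2 to compound 4 (0.10 log units; within the scatter)) and as trifluoromethoxy (a 1.0-fold higher number from compound 1 to compound 4 (0.00 log units; within the scatter)), with both steps within the scatter. A third group at this place on the aromatic carbon, and one that counts a hydrogen-bond acceptor where bromo counts none, has therefore still produced no shift. No measured evidence here offers a reason for this flat result.

As far as these compounds go, whether an amine or a carboxylic acid at this position would leave that level remains open. So does whether a longer chain would.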